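This account rests on a few compounds, and the source may have more. Where it says the series, first, only, none or still open, it means among the compounds named here.

Measured in a functional assay on DU-145 cells (Homo sapiens) for inhibition, read by trypan blue exclusion, with a stated time of 96 h; on this read-out higher numbers stand for weaker inhibition of growth and lower numbers for stronger inhibition of growth:
Compound 1 `O=C(/C(=C\c1ccc(Br)cc1)SCc1ccc(Cl)cc1)c1ccc(Br)cc1`: 1000 nM
Compound 2 `Cc1ccc(S(=O)(=O)/C(=C/c2ccc(O)c([N+](=O)[O-])c2)C(=O)c2ccc(Cl)cc2)cc1`: 25000 nM
Compound 3 `Cc1ccc(S(=O)(=O)/C(=C/c2sccc2C)C(=O)c2ccc(Cl)cc2)cc1`: 10000 nM

Compound 2 has the highest number of the three. Compound 4 `O=C(/C(=C\c1ccc(O)c([N+](=O)[O-])c1)SCc1ccccc1Cl)c1ccc(Cl)cc1` differs from it in one place ((2-chlorobenzyl)sulfanyl in place of (4-methylphenyl)sulfonyl on a double-bonded chain carbon bound to a carbonyl carbon and a double-bonded chain carbon). Among the compounds with values here, the one measured single change, a 2.5-fold lower number from compound 2 to compound 3 (0.40 log units; beyond the scatter), lies at another place, so it bears on this exchange only weakly, and no measured step covers the exchange itself. The nearest hint is compound 1 at 1000 nM, which also carries a chlorobenzyl sulfanyl group but differs elsewhere too. A lower number, larger than that modest step, is therefore expected in this assay, and the estimated change is a 6.3-fold lower number from compound 2 to compound 4 (0.80 log units; beyond the scatter). The expected value for compound 4 is 4000 nM, with an estimated range of 800 nM to 20000 nM.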

Compound 4, concentration for 50% growth inhibition: 10000 nM
Compound 4: middle estimate off by 2.5-fold (0.40 log units), on the low side; the range from low to high includes it.
By their numbers in this assay, from the lowest: compound 1; then compounds 3 and 4 (each within the scatter of the next); then compound 2.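

In this assay, placing (2-chlorobenzyl)sulfanyl instead of (4-methylphenyl)sulfonyl on the double-bonded chain carbon bound to a carbonyl carbon and a double-bonded chain carbon gives a 2.5-fold lower number from compound 2 to compound 4 (0.40 log units; beyond the scatter). Within the data shown here, this is the first measured step at this place, and it shows that growth inhibition here does not depend on the (4-methylphenyl)sulfonyl group. Nothing measured accounts for this step. The compounds shown leave open whether the sulfur linkage or the chlorobenzyl part carries the change, since both differ at once. They also leave open how an amine or a longer chain would fare at this place.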